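This account rests on a few compounds, and the source may have more. Where it says the series, first, only, none or still open, it means among the compounds named here.

Of the compounds shown here, two sharing the same core have numbers so far in a functional assay on A549 cells (Homo sapiens) for antiproliferative activity, read by MTT assay, with a stated time of 48 h; on this read-out higher numbers stand for weaker inhibition and lower numbers for stronger inhibition. Compound 1 `Cc1ccc(-c2nnc(NC(=O)/C=C/c3ccc(C(F)(F)F)cc3)s2)cc1` gives 1.61 ug/mL, and compound 2 `Cc1ccc(/C=C/C(=O)Nc2nnc(-c3ccc(C)cc3)s2)cc1` gives 1.08 ug/mL. For the measured compounds named here, these two values lie within the usual scatter of each other, so compound 2 cannot be separated from its only measured neighbour. Compound 3 `Cc1ccc(-c2nnc(NC(=O)/C=C/c3ccccc3)s2)cc1` carries one small edit relative to compound 2: hydrogen in place of methyl on an aromatic carbon. In words, this is hydrogen in place of methyl on an aromatic carbon. Going by the values given here, one measured step bears on it, a swap on that same aromatic carbon: a 1.5-fold lower number from compound 1 to compound 2 (0.17 log units; within the scatter). A single step is thin evidence, but it gives no reason to expect a change beyond the scatter in this assay, in either direction. Compound 3 is expected near 1.3 ug/mL, with an estimated range from 0.6 ug/mL to 2.7 ug/mL. This estimate means an expected 1.2-fold higher number from compound 2 to compound 3 (0.08 log units; within the scatter).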

Compound 3, half-maximal inhibitory concentration: 1.38 ug/mL
The estimate for compound 3 lay 1.1-fold (0.03 log units) below the measured number; measured number inside the range.
By their numbers in this assay, from the lowest: compounds 2, 3 and 1 (each within the scatter of the next).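

In this assay, taking the methyl off to turn 4-methylphenyl into phenyl gives a 1.3-fold higher number from compound 2 to compound 3 (0.11 log units; within the scatter) and, on the same aromatic carbon, hydrogen in place of trifluoromethyl gives a 1.2-fold lower number from compound 1 to compound 3 (0.07 log units; within the scatter). The earlier pair compared two substituents only, whereas compound 3 adds the unsubstituted ring as a reference: neither methyl nor trifluoromethyl can be told apart from hydrogen here, and all three compounds lie within the scatter of one another. No supporting measurement is available to help interpret this flat result.

From the compounds shown here alone, it remains open whether a group such as an amine, a carboxylic acid or a longer chain like butyl on this carbon would move the number beyond the scatter. These three compounds also say nothing about changes elsewhere in the shared core.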